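Series notes: amine chain pruning and stability in lung tissue

A few compounds are considered here, and "the series" means these few. Any claim that something is new, unique, unknown or untested is made for them only; others in the source may bear on it.

Measured so far:
Compound 1 `Cc1csc2cc([C@H](C)Nc3ncnc(N)c3C#N)c(-c3cccc(CN4CCC(N(C)CC(C)C)CC4)c3)c(=O)n12`: 2.8% in an ADME assay on the whole organism (lung, Rattus norvegicus) for metabolic stability, read by LC-MS, with a stated time of 24 h; on this read-out higher numbers stand for a more stable compound and lower numbers for a less stable compound
Compound 2 `Cc1csc2cc([C@H](C)Nc3ncnc(N)c3C#N)c(Cc3cccc(CN(C)CC(C)C)c3)c(=O)n12`: 0% in this assay

Compound 2 carries the lower of the two numbers, though the gap to compound 1 lies within the scatter, so the two compounds cannot be ordered. Compound 3 `Cc1csc2cc([C@H](C)Nc3ncnc(N)c3C#N)c(Cc3cccc(CN(C)C)c3)c(=O)n12` differs from compound 2 by hydrogen in place of isopropyl on a saturated chain carbon bound to an amine nitrogen. Going by the values given here, no step between measured compounds exists to gauge this change, so for compound 3 a step no larger than the scatter is expected, a number 2 percentage points higher from compound 2 to compound 3 (within the scatter). For compound 3 the expected value in this assay is 2%, with a range from 0% to 12%.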

Compound 3, percent of the compound remaining: 0%
The estimate for compound 3 lay 2 percentage points above the measured number; measured number inside the range.
By their numbers in this assay, from the lowest: compounds 2, 3 and 1 (each within the scatter of the next).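

In this assay, cutting isobutyl(methyl)amino back to dimethylamino gives no change at the digits printed from compound 2 to compound 3 (within the scatter), so removing the isopropyl leaves the number where it was. With compound 3 at 0%, the shorter amine chain offers no readable gain at this position. No measurement at hand explains this result.

Still open, as far as these compounds go, is whether a different group on this amine, such as a morpholine or a carboxylic acid, would move the number beyond the scatter. Also open, from the compounds shown here alone, is whether replacing the amine altogether would do so.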